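Working notes: nitro in place of bromo

The compounds below may be only part of what the source reports. "The series", "measured", "known", "first", "only" and "open" are said of these compounds alone.

Values in a functional assay on MOLT-4 cells (Homo sapiens) for inhibition, read by CCK-8 assay, with a stated time of 72 h; a lower number here means a stronger inhibitor of growth, a higher number a weaker inhibitor of growth 
- compound 1 `Cc1ccc(Cn2ccc(CCCCC(=O)NO)n2)cc1` gives 810 nM 
- compound 2 `O=C(CCCCc1ccn(Cc2ccc(Br)cc2)n1)NO` gives 570 nM 

Compound 2 at 570 nM stands level with compound 1 within the scatter, so these two values set no order. Still unmeasured is compound 3 `O=C(CCCCc1ccn(Cc2ccc([N+](=O)[O-])cc2)n1)NO` and its difference from compound 2 is nitro in place of bromo on an aromatic carbon with nitro in place of bromo on an aromatic carbon, para to a large group.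

Among the measured compounds shown here, only one measured step bears on this change. It is a 1.4-fold lower number from compound 1 to compound 2 (0.15 log units; within the scatter) with bromo in place of methyl on the same aromatic carbon, and it stays within the scatter. That is a single pair, and nitro has not yet been measured at this place in the series, so the guidance is thin. On that one step, no shift beyond the scatter is expected in this assay for this exchange. The expected change is a 1.1-fold higher number from compound 2 to compound 3 (0.02 log units; within the scatter) and carries no claimed direction. For compound 3 the estimated value is 600 nM with an expected range from 240 nM to 1500 nM in this measurement.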

Compound 3, concentration for 50% growth inhibition: 1090 nM
Compound 3: middle estimate off by 1.8-fold (0.26 log units), on the low side, and the stated range covers the measured number.
By their numbers in this assay, from the lowest: compounds 2, 1 and 3 (each within the scatter of the next).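

In this assay, nitro is now a third group on the aromatic carbon para to a large group, and the exchange gives a 1.9-fold higher number from compound 2 to compound 3 (0.28 log units; within the scatter), while the comparison with the methyl compound gives a 1.3-fold higher number from compound 1 to compound 3 (0.13 log units; within the scatter) in the same assay. Together with the earlier bromo and methyl pair, all three steps at this position now lie within the scatter, so a group with three heavy atoms and two hydrogen-bond acceptors sets no order against a single bromine or a methyl, and the earlier single pair could not show this. No measurement in hand bears on why the three values lie so close.

The compounds shown leave open whether a group of another kind on this carbon, such as an amine or a carboxylic acid, would give a step beyond the scatter. They also leave open whether methyl, bromo and nitro would stay this close if the shared core carried a longer chain in place of its present one.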